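Aryl change on the shared core: working notes

The source may hold more compounds than are shown below. What is called first, only, known or untested is meant among the compounds shown, and "the series" means these compounds.

- compound 1 `Cc1ccc(CNc2nc(Nc3ccc(N4CCN(C)CC4)cn3)ncc2Cl)cc1`: 12700 nM
- compound 2 `COc1ccccc1CNc1nc(Nc2ccc(N3CCN(C)CC3)cn2)ncc1Cl`: 10800 nM
- compound 3 `CC(C)c1cccc(Nc2nc(Nc3ccc(N4CCN(C)CC4)cn3)ncc2Cl)c1`: 12300 nM

In a functional assay on Jurkat cells (Homo sapiens) for inhibition, read by CCK-8 assay, with a stated time of 48 h (on this read-out higher numbers stand for weaker inhibition of growth and lower numbers for stronger inhibition of growth), compound 3 gives 12300 nM, level with the other two compounds within the scatter. Compound 4 `Cc1cc(C)c(Nc2nc(Nc3ccc(N4CCN(C)CC4)cn3)ncc2Cl)c(C)c1` carries 2,4,6-trimethylphenyl in place of 3-isopropylphenyl on a nitrogen on an aromatic ring. Two measured changes at this nitrogen bear on it: a 1.0-fold lower number from compound 1 to compound 3 (0.01 log units; within the scatter) and a 1.1-fold higher number from compound 2 to compound 3 (0.06 log units; within the scatter). A third, a 1.2-fold lower number from compound 1 to compound 2 (0.07 log units; within the scatter), also stayed small. Within the data shown here, none of the three leaves the scatter, though no measured compound carries the entering group. In this assay the expected step is a 1.0-fold lower number from compound 3 to compound 4 (0.01 log units; within the scatter), with no change beyond the scatter anticipated. For compound 4 the estimate is 12000 nM, with an expected range of 6000 nM to 25000 nM.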

Compound 4, concentration for 50% growth inhibition: 7600 nM
Compound 4: the middle estimate sits 1.6-fold (0.20 log units) above what was measured; measured number inside the range.
By their numbers in this assay, from the lowest: compounds 4, 2, 3 and 1 (each within the scatter of the next).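

In this assay the same carbon count rearranged, from 3-isopropylphenyl to 2,4,6-trimethylphenyl on this nitrogen, gives a 1.6-fold lower number from compound 3 to compound 4 (0.21 log units; within the scatter) and adds a ring bearing three methyl groups to the set. Against the two benzyl groups, the entering group gives a 1.4-fold lower number from compound 2 to compound 4 (0.15 log units; within the scatter) and a 1.7-fold lower number from compound 1 to compound 4 (0.22 log units; within the scatter) so all four compounds remain level on this read-out. No measurement at hand bears on the reason for these small steps. As far as these compounds go, whether an amine, a carboxylic acid or a longer chain on this nitrogen would move the number beyond the scatter stays open.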